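The source may hold more compounds than are shown below. What is called first, only, known or untested is meant among the compounds shown, and "the series" means these compounds.

Among the measured compounds shown here, in an ADME assay on BE(2)-C cells (Homo sapiens) for cytotoxicity, read by MTT assay, with a stated time of 20 h (on this read-out higher numbers stand for lower toxicity in this test and lower numbers for higher toxicity in this test), compound 2 (`CC(C)Cn1c(C(=O)N2CCC(C(=O)N(C)Cc3ccccc3)CC2)cc2ccccc21`) gives 58200 nM, the only true number available so far. Compound 1 (`CC(=O)n1c(C(=O)N2CCC(C(=O)N(C)Cc3ccccc3)CC2)cc2ccccc21`) reports only a limit, > 50000 nM. For the measured compounds named here, the comparison of these two, with isobutyl in place of acetyl on an aromatic nitrogen, is a step that the limit leaves unreadable from compound 1 to compound 2, so the sole measured step offers no size to carry forward, and the limit of > 50000 nM in this assay, at which 1 of the 2 values shown sits, is all that stands beside it. Compound 3 (`CN(Cc1ccccc1)C(=O)C1CCN(C(=O)c2cc3ccccc3n2Cc2ccccc2)CC1`) differs from compound 2 by phenyl in place of isopropyl on a saturated chain carbon bound to an aromatic nitrogen, which also reads as isobutyl to benzyl. Going by the values given here, no measured step covers this change, so the expectation rests on compound 2 at 58200 nM, and no shift beyond the scatter is expected in this assay. The expected move is a 1.3-fold lower number from compound 2 to compound 3 (0.11 log units; within the scatter). For compound 3 the estimate is 45000 nM, with an expected range of 18000 nM to 110000 nM.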

Compound 3, half-maximal cytotoxic concentration: 64800 nM
Estimate against measurement, compound 3: 1.4-fold (0.16 log units) below; low and high end bracket the measured number.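

In this assay, the exchange of isopropyl for phenyl on a saturated chain carbon bound to an aromatic nitrogen, which also reads as isobutyl to benzyl, gives a 1.1-fold higher number from compound 2 to compound 3 (0.05 log units; within the scatter). Among the compounds shown here, this is the first step at this position with a readable size, and it shows that a six-membered aromatic ring of carbon only can take the place of isopropyl here without a shift beyond the scatter. Compound 1 gives only a limit, > 50000 nM, and the steps from compound 1 cannot be read because of it: the limit of > 50000 nM in this assay, at which 1 of the 3 values shown sits.

The compounds shown leave open whether an amine or a carboxylic acid on this chain would move the number in this assay beyond the scatter. Going by these compounds, a longer chain ending in phenyl at the same place is equally open.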